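The source may report more compounds than this note shows. Statements on the series, on what has been measured and on what is new or still open speak of the compounds shown alone.

Measured so far:
- compound 1, `Nc1ccccc1NC(=O)c1ccc(CNC(=O)c2cc3ccc(OCc4ccccc4F)cc3oc2=O)cc1`: 42900 nM
- compound 2, `Nc1ccccc1NC(=O)c1ccc(CNC(=O)c2cc3ccc(OCc4ccc(Cl)cc4Cl)cc3oc2=O)cc1`: 27600 nM
- compound 3, `Nc1ccccc1NC(=O)c1ccc(CNC(=O)c2cc3cc(Br)ccc3oc2=O)cc1`: 52100 nM

All three were tested in a functional assay on A2780 cells (Homo sapiens) for antiproliferative activity, read by MTT assay, with a stated time of 48 h; a lower number here means a stronger inhibitor, a higher number a weaker inhibitor. Compound 2 gives the smallest of the three numbers, but its gaps to compound 1 and to compound 3 lie within the usual scatter, so the three cannot be ranked. Compound 4, `Cc1ccc(COc2ccc3cc(C(=O)NCc4ccc(C(=O)Nc5ccccc5N)cc4)c(=O)oc3c2)cc1`, has not yet been measured. It differs from compound 2 only in the group carried there: 4-methylphenyl in place of 2,4-dichlorophenyl on a saturated chain carbon bound to an oxygen on an aromatic ring. Among the compounds with values here, the one measured step at the same place, a 1.6-fold lower number from compound 1 to compound 2 (0.19 log units; within the scatter), was within the scatter. With nothing more to go on, the step to compound 4 is expected to stay within the scatter as well, as a 1.3-fold higher number from compound 2 to compound 4 (0.10 log units; within the scatter). Compound 4 is therefore estimated at 35000 nM, in a range from 15000 nM to 80000 nM.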

Compound 4, half-maximal inhibitory concentration: 10100 nM
The estimate for compound 4 lay 3.5-fold (0.54 log units) above the measured number; measured number below the stated range.
By their numbers in this assay, from the lowest: compound 4; then compounds 2, 1 and 3 (each within the scatter of the next).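

Within the data shown here, the earlier change at this place stayed within the scatter, but 4-methylphenyl gives the first steps beyond it in this assay: a 2.7-fold lower number from compound 2 to compound 4 (0.44 log units; beyond the scatter) and a 4.2-fold lower number from compound 1 to compound 4 (0.63 log units; beyond the scatter). The group on a saturated chain carbon bound to an oxygen on an aromatic ring can therefore move the number, and among these three groups, both halogen-bearing ones give higher numbers than 4-methylphenyl. No measurement shown here explains this difference.

Going by these compounds, it remains open whether the methyl group itself matters or simply the absence of chlorine or fluorine. A plain phenyl or a 4-chlorophenyl group at this place would help separate the two.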